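The source may hold more compounds than are shown below. What is called first, only, known or untested is meant among the compounds shown, and "the series" means these compounds.

Three compounds sharing a purine-like framework have been examined in an assay on isolated protein for inhibition of Ca2+/calmodulin-dependent protein kinase II (CaM kinase II) (Rattus norvegicus), tested at 30 uM; a higher number here means more inhibition at the concentration tested (going by the name of the read-out), a lower number less inhibition. Compound 1 `Cn1cnc2c(Nc3ccccc3)ncnc21` gives 0% in this assay. Compound 2 `Cn1cnc2c(Nc3ccc(F)cc3)ncnc21` differs from compound 1 by a single change, (fluoro in place of hydrogen on an aromatic carbon), and in this assay compound 2 gives 8%. The step is a number 8 percentage points higher from compound 1 to compound 2 (within the scatter).

Compound 3 `Clc1ncnc2c1ncn2Cc1ccccc1` carries a different core from compound 1; the difference between the two cores is not broken down here. In this assay compound 3 gives 7%. Its number stands closest to that of compound 2, and the gap to compound 1 is also within the scatter, so none of the three can be placed in any order of inhibition.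

Compound 4 `Fc1ccc(Cn2cnc3c(Cl)ncnc32)cc1` has not been measured in this assay. For the measured compounds named here, it differs from compound 3 by fluoro in place of hydrogen on an aromatic carbon, which is the same change as the one from compound 1 to compound 2: the leaving hydrogen, the entering fluoro and the place, on an aromatic carbon of a six-membered aromatic ring of carbon only, para to a large group, match word for word. The step from compound 3 to compound 4 is expected to be a number 3 percentage points higher from compound 3 to compound 4 (within the scatter) because the same change gave a number 8 percentage points higher from compound 1 to compound 2 (within the scatter). In this assay compound 4 is therefore estimated at 10%, with a plausible range from 0% to 20%. The account resumes once compound 4 has been measured.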

Compound 4, a percentage reported as inhibition, at one concentration (the size of the read-out at that concentration, not a potency): 0%
Compound 4: the middle estimate sits 10 percentage points above what was measured, and the stated range covers the measured number.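

Fluoro in place of hydrogen on an aromatic carbon, para to a large group, gives in this assay a number 7 percentage points lower from compound 3 to compound 4 (within the scatter). Set beside the earlier step, this shows that the change did not carry over unaltered from the core of compound 1 to the core of compound 3, so the result on one of these cores gave no reliable reading of the result on the other: the same change on two cores in this assay, a number 8 percentage points higher (within the scatter) from compound 1 to compound 2 and a number 7 percentage points lower (within the scatter) from compound 3 to compound 4, 15 percentage points apart, beyond the scatter of two such steps It does not show that fluoro raises inhibition on one core or lowers it on the other, since each step on its own lies within the scatter, and with a single pair on each core the difference between the two steps cannot be extended into a rule for the series.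

The compounds shown leave open whether any other group at this place on the aromatic ring, such as methoxy, an amine or a carboxylic acid, would give a step beyond the scatter in this assay. They also leave open what an amine in place of the chloro of compound 3, or a longer chain in place of the methyl of compound 1, would give.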